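Thiophene for pyridine on two related chlorophenyl pyridine cores

The source may hold more compounds than are shown below. What is called first, only, known or untested is meant among the compounds shown, and "the series" means these compounds.

Compound 1 `Oc1ccc(-c2cc(-c3ccc(Cl)cc3)nc(-c3cccnc3)c2)cc1` and compound 2 `Oc1ccc(-c2cc(-c3ccc(Cl)cc3)nc(-c3cccs3)c2)cc1` share one core; compound 3 `Oc1cccc(-c2cc(-c3cccnc3)nc(-c3ccccc3Cl)c2)c1` has the same atoms joined differently, and the difference between the two cores is not broken down here. In an assay on isolated protein for inhibition of DNA topoisomerase 1 (Homo sapiens), with a stated time of 30 min, tested at 100 uM (on this read-out higher numbers stand for a stronger effect at the one concentration tested and lower numbers for a weaker effect), compound 1 gives 18.8%. Compound 2 carries thiophen-2-yl in place of pyridin-3-yl, (thiophen-2-yl in place of pyridin-3-yl on an aromatic carbon), and in this assay compound 2 gives 38.8%, so that a number 20 percentage points higher from compound 1 to compound 2 (beyond the scatter). Compound 3 sits lowest of the three: in this assay compound 3 gives 0%, which lies beyond the scatter from compound 1 and from compound 2.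

Compound 4 `Oc1cccc(-c2cc(-c3cccs3)nc(-c3ccccc3Cl)c2)c1` is not yet measured. It stands to compound 3 as compound 2 stands to compound 1: thiophen-2-yl in place of pyridin-3-yl on an aromatic carbon. This is the same kind of change as that from compound 1 to compound 2, not the same change: the place is described once as meta to a 4-chlorophenyl group and a 4-hydroxyphenyl group, and here as meta to a 2-chlorophenyl group and a 3-hydroxyphenyl group. Going by the values given here, the only guide is the single earlier step, a number 20 percentage points higher from compound 1 to compound 2 (beyond the scatter), made on a core whose start was itself modest; compound 3 starts from the weakest number of the set. The expected step from compound 3 to compound 4 in this assay is a number 12 percentage points higher from compound 3 to compound 4 (beyond the scatter), somewhat smaller than the earlier one, because it rests on a number 20 percentage points higher from compound 1 to compound 2 (beyond the scatter) alone. For compound 4 in this assay a value of 12% is estimated, with a range from 0% to 35%.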

Compound 4, a percentage reported as inhibition, at one concentration (the size of the read-out at that concentration, not a potency): 2.7%
Compound 4: middle estimate off by 9.3 percentage points, on the high side, within the range that was stated.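

In this assay, placing thiophen-2-yl in place of pyridin-3-yl on the core of compound 3 gives a number 2.7 percentage points higher from compound 3 to compound 4 (within the scatter), so on this core the change produces no readable effect, in contrast to a number 20 percentage points higher from compound 1 to compound 2 (beyond the scatter) on the core of compound 1. Going by these compounds alone, the size of the step therefore does not carry from one core to the other, and the gain seen on the core of compound 1 cannot be assumed for this type of change across the series: the same change on two cores in this assay, a number 20 percentage points higher (beyond the scatter) from compound 1 to compound 2 and a number 2.7 percentage points higher (within the scatter) from compound 3 to compound 4, 17.3 percentage points apart, beyond the scatter of two such steps This rests on only two matched pairs, each read at one concentration, so it shows that the step depends on the core in these four compounds but gives no rule for any other core and no reason for the gap.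

The two cores differ in both the chlorophenyl and the hydroxyphenyl group, and the compounds shown leave open which of these two differences, or the pair together, goes with the loss of the step. Also open, as far as these compounds go, is how a group such as an amine or a carboxylic acid on that aromatic carbon would read on either core.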